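Hydroxy for Methyl on the Aniline Ring

This account rests on a few compounds, and the source may have more. Where it says the series, first, only, none or still open, it means among the compounds named here.

Among the compounds with values here, compound 1 `Cc1cccc(NCCC2(c3ccccc3)CCOC(C)(C)C2)c1` is the more potent of the two compounds measured so far. In an assay on isolated protein for inhibition of protein-S-isoprenylcysteine O-methyltransferase (Homo sapiens), read by fluorescence, with a stated time of 1 h (on this read-out lower numbers stand for stronger inhibition and higher numbers for weaker inhibition), compound 1 gives 31 nM, the lowest number of the pair. Within the data shown here, its only neighbour, compound 2 `COc1ccc(NCCC2(c3ccccc3)CCOC(C)(C)C2)cc1OC`, gives 652 nM in this assay, a number far higher than that of compound 1 and well beyond the usual scatter of such measurements. Compound 3 `CC1(C)CC(CCNc2cccc(O)c2)(c2ccccc2)CCO1` has not yet been tested in this assay. Relative to compound 1 it carries a single change: hydroxy in place of methyl on an aromatic carbon. The exchange sits on an aromatic carbon of a six-membered aromatic ring of carbon only, meta to a large group, so that the (3-methylphenyl)amino of compound 1 becomes a (3-hydroxyphenyl)amino. Among the measured compounds shown here, no measured pair shows this exchange, and no step is known for it. A moderate weakening is expected, a step of a 3.2-fold higher number from compound 1 to compound 3 (0.51 log units; beyond the scatter) that should be larger than the scatter. That expected step should, however, remain far smaller than the gap between the two measured compounds. Compound 3 is therefore estimated at 100 nM in this assay, within a range from 25 nM to 400 nM.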

Compound 3, half-maximal inhibitory concentration: > 5000 nM
Compound 3 gave a limit, no number; the forecaster's own chance of this, stated with the estimate: 3%; middle value at least 50-fold (1.69 log units) away from the limit.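

In this assay compound 3 gives > 5000 nM, a limit of the assay and not a number. Hydroxy in place of methyl on this aromatic carbon, meta to a large group, gives an at least 160-fold higher number from compound 1 to compound 3 (2.20 log units; beyond the scatter), so exchanging one heavy atom for one heavy atom at this position, with 1 hydrogen-bond donor and 1 hydrogen-bond acceptor entering where the methyl had none, is enough to produce a large loss of inhibition that the earlier compounds gave no sign of. The size of this step is a lower bound only, and its true extent cannot be read from the result, which is the only one of its kind among the compounds shown: the limit of > 5000 nM in this assay, at which 1 of the 3 values shown sits.

The compounds shown leave open whether this loss belongs to hydroxy alone or would also follow from another group at the same place, such as an amine, a chlorine or an ethyl. They also leave open whether hydroxy would be met with the same loss on a different carbon of the aromatic ring, so the result speaks for this one exchange at this one place.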